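Methyl in Place of Fluoro on the Shared Core

The compounds below may be only part of what the source reports. "The series", "measured", "known", "first", "only" and "open" are said of these compounds alone.

Compound 1 `O=C(O)CCc1ccc2[nH]c(-c3ccccc3F)cc2c1` carries a 2-fluorophenyl group on the shared core. For the measured compounds named here, in a functional assay on CHO cells for agonist activity at Free fatty acid receptor 1 (Homo sapiens), read by a luciferase reporter, with a stated time of 24 h (a lower number here means that less compound is needed, a higher number that more compound is needed for the effect), compound 1 gives 1210 nM, and this is the only measured number among the three compounds described here. Compound 2 `COc1cccc(-c2cc3cc(CCC(=O)O)ccc3[nH]2)c1` is reported in this assay only as a limit of the assay, > 25 nM, not as a number. Compound 3 `COc1ccc(-c2cc3cc(CCC(=O)O)ccc3[nH]2)cc1` likewise reaches in this assay only a limit of the assay, > 25 nM. Going by the values given here, compound 1 therefore stands alone with a value, while the other two sit at the limit of > 25 nM in this assay, at which 2 of the 3 values shown sit, so no measured step between two numbered values can be drawn from them.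

Compound 4 `Cc1ccccc1-c1cc2cc(CCC(=O)O)ccc2[nH]1` is not yet measured. It differs from compound 1 in one place: methyl in place of fluoro on an aromatic carbon, which reads, cut one bond further out, as 2-fluorophenyl becoming 2-methylphenyl. Among the compounds with values here, since no step between measured compounds exists, the expectation rests on the lone value of compound 1 together with the small size of the change. The step from compound 1 to compound 4 in this assay is expected to be a 1.5-fold lower number from compound 1 to compound 4 (0.18 log units; within the scatter), a modest shift toward lower concentration that may not exceed the usual scatter. For compound 4 the expected value in this assay is 800 nM, with a likely range from 200 nM to 3000 nM.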

Compound 4, half-maximal effective concentration: 447 nM
Compound 4: middle estimate off by 1.8-fold (0.25 log units), on the high side, within the range that was stated.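

In this assay, for the compounds shown here, the exchange of 2-fluorophenyl for 2-methylphenyl gives a 2.7-fold lower number from compound 1 to compound 4 (0.43 log units; beyond the scatter) and is the first measured step on the shared core. It shows that this place on the aromatic ring, ortho to a large group, responds beyond the usual scatter to the replacement of one heavy atom by another, even though neither fluoro nor methyl brings a ring, a hydrogen-bond donor, a hydrogen-bond acceptor or a net charge. The result is a single step from a single pair of compounds, and nothing measured here explains it or bears on its cause.

Steps that involve compound 2 or compound 3 cannot be read, since each of them is reported only as a limit of the assay and not as a number. The compounds shown leave open how chloro, trifluoromethyl, methoxy or an amine would fare at this same place on the ring, and whether the methyl exchange would give a step of the same direction on a core with a longer chain in place of the propanoic acid.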